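The compounds below may be only part of what the source reports. "The series", "measured", "known", "first", "only" and "open" are said of these compounds alone.

Measured compounds in this series:
compound 1 `FC(F)(F)c1ccc(C2CC(c3ccccc3)=NN2c2ccc(-c3ccccc3)nn2)cc1` — 100000 nM
compound 2 `COc1ccc(C2CC(c3ccccc3)=NN2c2ccc(-c3ccccc3)nn2)cc1` — 100000 nM
compound 3 `COc1ccc(C2CC(c3ccccc3)=NN2c2ccc(-c3ccccc3)nn2)c(OC)c1` — > 100000 nM

In a functional assay on MCF7 cells (Homo sapiens) for antiproliferative activity, read by MTT assay, with a stated time of 24 h (on this read-out higher numbers stand for weaker inhibition and lower numbers for stronger inhibition), compound 1 gives 100000 nM and compound 2 gives 100000 nM. For compound 3 the assay reports only a limit, > 100000 nM. Compound 2 therefore stands level with compound 1 no change at the digits printed from compound 1 to compound 2 (within the scatter), and the change to compound 3 reads as a number no lower from compound 2 to compound 3 (the limit leaves the size open); from compound 1 the same comparison reads a number no lower from compound 1 to compound 3 (the limit leaves the size open). All values sit at the top of the measured range, one of them at the limit (the limit of > 100000 nM in this assay, at which 1 of the 3 values shown sits).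

The next compound, compound 4 `COc1ccc(C2CC(c3ccc(Cl)cc3)=NN2c2ccc(-c3ccccc3)nn2)cc1`, differs from compound 2 by chloro in place of hydrogen on an aromatic carbon. Within the data shown here, none of the measured steps touches this ring: the step from compound 1 to compound 2 and the step from compound 2 to compound 3 both alter the ring on the saturated ring carbon, and neither moved the read-out beyond the scatter. With no variation of the ring in question measured, and every value in the series already weak, no step beyond the scatter is expected for compound 4 in this assay no change at the digits printed from compound 2 to compound 4 (within the scatter). Compound 4 is estimated at 100000 nM, within 30000 nM to 100000 nM.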

Compound 4, half-maximal inhibitory concentration: 100000 nM
Beside the measured number, compound 4's estimate shows no gap at the digits printed; low and high end bracket the measured number.
By their numbers in this assay, from the lowest: compounds 1, 2 and 4 (each within the scatter of the next).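

In this assay, chloro in place of hydrogen, para to a large group on the six-membered aromatic ring, gives no change at the digits printed from compound 2 to compound 4 (within the scatter). Among these compounds, this is the first read on this ring, as the earlier steps altered only the aromatic group on the saturated ring carbon, so the read-out now stays flat for a change at a second place on the shared core. The flatness carries little resolution, however, as compounds 1, 2 and 4 all share one value near the top of the measured range and a further compound reaches the ceiling of the assay, which leaves little room to register any further weakening: the limit of > 100000 nM in this assay, at which 1 of the 4 values shown sits.

Going by these compounds, whether phenyl to 4-chlorophenyl has any effect of its own therefore stays open, and a single halogen says nothing about other groups at this place, such as an amine, a carboxylic acid or a longer alkyl chain. On these data alone, it also remains open whether any change on this ring, alone or combined with a different group on the saturated ring carbon, can bring the series down from the top of the range in this assay.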